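Benzyl in Place of Methyl at the Ring Amide Nitrogen

The compounds below may be only part of what the source reports. "The series", "measured", "known", "first", "only" and "open" are said of these compounds alone.

Compound 1 `C=CC(=O)N1CC[C@H](N2C(=O)N(C3CCCC3)Cc3cnc(Nc4ccc(N5CCN(C)CC5)cc4OC)nc32)C1`: 250 ug/mL
Compound 2 `C=CC(=O)NCCN1C(=O)N(Cc2ccccc2)Cc2cnc(Nc3ccc(N4CCN(C)CC4)cc3OC)nc21`: 96.7 ug/mL
Compound 3 `C=CC(=O)N1CC[C@H](N2C(=O)N(C)Cc3cnc(Nc4ccc(N5CCN(C)CC5)cc4OC)nc32)C1`: 1250 ug/mL

In a physicochemical assay for solubility, read by HPLC, in phosphate buffer, measured as thermodynamic solubility, with a stated time of 24 h, at pH 6.8 (a lower number here means a less soluble compound, a higher number a more soluble compound), compound 3 gives the highest of the three numbers; compound 1 sits a 5.0-fold higher number from compound 1 to compound 3 (0.70 log units; beyond the scatter) below it, and compound 2 lies further down still. Compound 4 `C=CC(=O)N1CC[C@H](N2C(=O)N(Cc3ccccc3)Cc3cnc(Nc4ccc(N5CCN(C)CC5)cc4OC)nc32)C1` differs from compound 3 by phenyl in place of hydrogen on a saturated chain carbon bound to an amide-type nitrogen in a ring. Within the data shown here, the one step that bears on this change is the step from a larger to a smaller group on the same nitrogen, a 5.0-fold higher number from compound 1 to compound 3 (0.70 log units; beyond the scatter), which went against size. Compound 2, which also carries the benzyl group, gives 96.7 ug/mL, but its chain differs too, so only its value can be read. A drop beyond the scatter is therefore expected for compound 4, about a 6.9-fold lower number from compound 3 to compound 4 (0.84 log units; beyond the scatter). Compound 4 is estimated at 180 ug/mL, with a range of 60 ug/mL to 500 ug/mL.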

Compound 4, solubility: 107 ug/mL
Estimate against measurement, compound 4: 1.7-fold (0.23 log units) above; the measured number falls inside the stated range.
By their numbers in this assay, from the lowest: compounds 2 and 4 (each within the scatter of the next); then compound 1; then compound 3.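

In this assay the change from methyl to benzyl on the amide-type nitrogen in a ring can now be read directly, as a 12-fold lower number from compound 3 to compound 4 (1.07 log units; beyond the scatter) on an otherwise unchanged compound. Benzyl in place of cyclopentyl on that nitrogen gives a 2.3-fold lower number from compound 1 to compound 4 (0.37 log units; beyond the scatter) and sets the three groups in one order, with methyl highest and benzyl lowest. With benzyl held, 1-(vinylcarbonyl)pyrrolidin-3-yl in place of 2-((vinylcarbonyl)amino)ethyl gives a 1.1-fold higher number from compound 2 to compound 4 (0.04 log units; within the scatter) and does not separate the two chains. From the compounds shown here alone, whether an ethyl group, or a benzyl carrying an amine on its phenyl, would fit this order remains open. Nothing given here explains these steps.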